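Aryl urea variation: expectation for compound 4

The source may hold more compounds than are shown below. What is called first, only, known or untested is meant among the compounds shown, and "the series" means these compounds.

Compound 1 `CN(C)CCCn1cnnc1-c1cc(Oc2ccc(NC(=O)Nc3cccc(C(F)(F)F)c3)cc2F)ccn1`: 1790 nM in a functional assay on NCI-H460 cells (Homo sapiens) for antiproliferative activity, read by MTT assay, with a stated time of 72 h; on this read-out lower numbers stand for stronger inhibition and higher numbers for weaker inhibition
Compound 2 `CN(C)CCCn1cnnc1-c1cc(Oc2ccc(NC(=O)Nc3ccccc3C(F)(F)F)cc2F)ccn1`: 10900 nM in this assay
Compound 3 `CN(C)CCCn1cnnc1-c1cc(Oc2ccc(NC(=O)Nc3ccc(F)c(Cl)c3)cc2F)ccn1`: 1270 nM in this assay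

Compound 3 gives the lowest of the three numbers; the step of a 1.4-fold lower number from compound 1 to compound 3 (0.15 log units; within the scatter) lies within the scatter, so compounds 1 and 3 are not separated, while an 8.6-fold lower number from compound 2 to compound 3 (0.93 log units; beyond the scatter) is beyond it. Compound 4 `CN(C)CCCn1cnnc1-c1cc(Oc2ccc(NC(=O)Nc3ccc(Cl)cc3Cl)cc2F)ccn1` differs from compound 3 by 2,4-dichlorophenyl in place of 3-chloro-4-fluorophenyl on an amide-type nitrogen. The bearing precedent is compound 2, whose 2-(trifluoromethyl)phenyl is the nearest named pattern to 2,4-dichlorophenyl: a 6.1-fold higher number from compound 1 to compound 2 (0.78 log units; beyond the scatter) and an 8.6-fold lower number from compound 2 to compound 3 (0.93 log units; beyond the scatter) both point to a higher number for such an aryl. Within the data shown here, a step in that direction is therefore expected in this assay, probably smaller than those, since chlorine is not trifluoromethyl; no direct precedent exists. Compound 4 is expected to give 5000 nM (range 1800 nM to 14000 nM), corresponding to an expected step of a 3.9-fold higher number from compound 3 to compound 4 (0.60 log units; beyond the scatter).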

Compound 4, half-maximal inhibitory concentration: 3680 nM
For compound 4 the middle estimate is 1.4-fold (0.13 log units) above the measured one; the range from low to high includes it.
By their numbers in this assay, from the lowest: compounds 3 and 1 (each within the scatter of the next); then compound 4; then compound 2.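

In this assay, 2,4-dichlorophenyl on the amide-type nitrogen gives a level of its own: a 2.9-fold higher number from compound 3 to compound 4 (0.46 log units; beyond the scatter), a 2.1-fold higher number from compound 1 to compound 4 (0.31 log units; beyond the scatter) and a 3.0-fold lower number from compound 2 to compound 4 (0.47 log units; beyond the scatter) are all beyond the scatter. Among these four compounds, 2,4-dichlorophenyl and 2-(trifluoromethyl)phenyl both give higher numbers than 3-chloro-4-fluorophenyl and 3-(trifluoromethyl)phenyl, with no compound going against this, but the two are not equivalent.

On these data alone, whether 2-chlorophenyl or 4-chlorophenyl, each with a single chlorine, would match 2,4-dichlorophenyl remains open. Nothing shown explains these differences.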